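Replacing the hydroxynaphthyl group in a semicarbazone series

The compounds below may be only part of what the source reports. "The series", "measured", "known", "first", "only" and "open" are said of these compounds alone.

Going by the values given here, the three compounds measured so far share one core and differ only in the aryl group on a carbon with a double bond to nitrogen. Compound 1 `CN(C)CCn1cnnc1-c1cc(Oc2ccc(NC(=O)N/N=C/c3c(O)ccc4ccccc34)cc2F)ccn1` gives 890 nM in a functional assay on NCI-H460 cells (Homo sapiens) for cytotoxicity, read by MTT assay, with a stated time of 72 h (on this read-out higher numbers stand for weaker inhibition and lower numbers for stronger inhibition), the lowest of the three numbers. Compound 2 `CN(C)CCn1cnnc1-c1cc(Oc2ccc(NC(=O)N/N=C/c3ccc(F)cc3)cc2F)ccn1` gives 1980 nM, and compound 3 `COc1ccc(/C=N/NC(=O)Nc2ccc(Oc3ccnc(-c4nncn4CCN(C)C)c3)c(F)c2)c(OC)c1OC` gives 1790 nM; the step of a 2.0-fold higher number from compound 1 to compound 3 (0.30 log units; within the scatter) stays within the scatter, while a 2.2-fold higher number from compound 1 to compound 2 (0.35 log units; beyond the scatter) lies just beyond it.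

Compound 4 `CN(C)CCn1cnnc1-c1cc(Oc2ccc(NC(=O)N/N=C/c3ccc(O)cc3O)cc2F)ccn1` has not yet been measured. It differs from compound 1 in one place: 2,4-dihydroxyphenyl in place of 2-hydroxynaphthalen-1-yl on a carbon with a double bond to nitrogen.

Among the compounds with values here, two measured steps bear on this change, since both replace 2-hydroxynaphthalen-1-yl with another aryl group on the same carbon: a 2.2-fold higher number from compound 1 to compound 2 (0.35 log units; beyond the scatter) and a 2.0-fold higher number from compound 1 to compound 3 (0.30 log units; within the scatter). Both moved the number upward, one modestly and one within the scatter. Compound 4 is therefore expected to give a number somewhat higher than compound 1, a step of about a 1.5-fold higher number from compound 1 to compound 4 (0.16 log units; within the scatter), which would sit at the edge of the usual scatter. On that basis compound 4 is estimated at 1300 nM in this assay, with a likely range from 600 nM to 2800 nM.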

Compound 4, half-maximal inhibitory concentration: 11300 nM
Beside the measured number, compound 4's estimate is 8.7-fold (0.94 log units) below it; measured number outside the range, above it.
By their numbers in this assay, from the lowest: compounds 1, 3 and 2 (each within the scatter of the next, the first and the last beyond it); then compound 4.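

In this assay, going by these compounds alone, the aryl group on this carbon with a double bond to nitrogen tolerates less change than the earlier compounds suggested: 2,4-dihydroxyphenyl in place of 2-hydroxynaphthalen-1-yl gives a 13-fold higher number from compound 1 to compound 4 (1.10 log units; beyond the scatter) and is a far larger step than any seen before. The step is not simply the loss of the second aromatic ring, since 2,4-dihydroxyphenyl also stands apart from the other two replacements, with a 6.3-fold higher number from compound 3 to compound 4 (0.80 log units; beyond the scatter) and a 5.7-fold higher number from compound 2 to compound 4 (0.76 log units; beyond the scatter) among the groups shown. Carrying a hydroxyl does not by itself set the number either, as compound 1 and compound 4 both carry one and lie at opposite ends of the four, but the data shown hold no measurement that accounts for the separate standing of compound 4.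

On these data alone, how a phenyl group carrying a single hydroxyl, or one with methoxy groups in place of the two hydroxyls, would read in this assay remains open. The compounds shown therefore cannot tell whether the large step belongs to the pair of hydroxyls or to this particular arrangement on the ring.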